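From methyl to trifluoromethyl on a saturated ring carbon

The source may report more compounds than this note shows. Statements on the series, on what has been measured and on what is new or still open speak of the compounds shown alone.

In a functional assay (aorta) with Rattus norvegicus as the target (a higher number here means that more compound is needed for the effect, a lower number that less compound is needed), compound 3 (`CC1(C)C=C(C(=O)NCCC#N)c2cc([N+](=O)[O-])ccc2O1`) gives 2.82 nM. Compound 1 (`CNC(=O)C1=CC(C)(C(F)(F)F)Oc2ccc([N+](=O)[O-])cc21`) gives 2.69 nM, within the scatter of compound 3, while compound 2 (`CC1(C(F)(F)F)C=C(/C(S)=N\CCC#N)c2cc([N+](=O)[O-])ccc2O1`) gives a lower number, 0.363 nM.

Compound 4 (`CC1(C(F)(F)F)C=C(C(=O)NCCC#N)c2cc([N+](=O)[O-])ccc2O1`) has not yet been measured. It differs from compound 3 by a single change, trifluoromethyl in place of methyl on a saturated ring carbon, with the (2-cyanoethyl)carbamoyl group kept.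

For the measured compounds named here, no measured step makes this swap on its own. Going by the values given here, the one available step, a 7.4-fold lower number from compound 1 to compound 2 (0.87 log units; beyond the scatter), alters the group on a double-bonded ring carbon, and both of its compounds already carry trifluoromethyl, so it bears on the change only indirectly. Compound 1 also carries trifluoromethyl and compound 3 methyl, and their values lie within the scatter of each other, although their other groups differ as well. Compound 2, with trifluoromethyl, reaches 0.363 nM, so in this assay a small shift toward a lower number is expected, not a rise. The estimated change is a 1.7-fold lower number from compound 3 to compound 4 (0.22 log units; within the scatter). For compound 4 the estimate is 1.7 nM, with an expected range from 0.5 nM to 5.5 nM.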

Compound 4, half-maximal effective concentration: 0.692 nM
For compound 4 the middle estimate is 2.5-fold (0.39 log units) above the measured one; low and high end bracket the measured number.
By their numbers in this assay, from the lowest: compounds 2 and 4 (each within the scatter of the next); then compounds 1 and 3 (each within the scatter of the next).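

Trifluoromethyl in place of methyl on the saturated ring carbon next to the ring oxygen, with the (2-cyanoethyl)carbamoyl group kept, now has a reading of its own in this assay and comes out as a 4.1-fold lower number from compound 3 to compound 4 (0.61 log units; beyond the scatter), so this position responds to the change on its own, which no earlier step could show. With trifluoromethyl held in place, the chain on the amide nitrogen also matters, since cyanomethyl in place of hydrogen on the saturated chain carbon bound to that nitrogen gives a 3.9-fold lower number from compound 1 to compound 4 (0.59 log units; beyond the scatter). The sulfur-bearing group on the double-bonded ring carbon and the (2-cyanoethyl)carbamoyl group, by contrast, are not separated in this setting, as the swap between them gives a 1.9-fold higher number from compound 2 to compound 4 (0.28 log units; within the scatter).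

The compounds shown leave open whether the response at this ring carbon follows the number of fluorine atoms or the size of the group, which difluoromethyl, ethyl or pentafluoroethyl at the same carbon would begin to address. No measurement given here accounts for the step from methyl to trifluoromethyl.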